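Amino on the ring nitrogen: expected antiproliferative shift

The compounds below may be only part of what the source reports. "The series", "measured", "known", "first", "only" and "open" are said of these compounds alone.

Of the compounds shown here, two have been measured. Compound 1 `Cc1ccc(-c2nc3ccc(Cl)cc3c(=S)[nH]2)cc1` gives 7.01 ug/mL in a functional assay on HepG2 cells (Homo sapiens) for antiproliferative activity, read by MTT assay, with a stated time of 48 h; a higher number here means a weaker inhibitor, a lower number a stronger inhibitor. Compound 2 `Cc1ccc(-c2nc(NO)c3cc(Cl)ccc3n2)cc1` gives in this assay 23.1 ug/mL. Compound 1 holds the lowest number of the two; the nearest value, that of compound 2, is higher by an amount beyond the usual scatter. Among the measured compounds shown here, no pair of measured compounds differs at one place only, so no single structural step has yet been characterised within the set.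

Compound 3 `Cc1ccc(-c2nc3ccc(Cl)cc3c(=S)n2N)cc1` is not yet measured. It differs from compound 1 by amino in place of hydrogen on an aromatic nitrogen. The shared core of compound 1 is otherwise retained.

Nothing measured here shows what this change does. For the measured compounds named here, with no matched step to lean on, the expectation is a small step, not clearly beyond the scatter, in either direction. Compound 3 is therefore expected to give about 8 ug/mL in this assay, with a range of 3 ug/mL to 20 ug/mL. This estimate means a step of a 1.1-fold higher number from compound 1 to compound 3 (0.06 log units; within the scatter) that is expected to stay within the usual scatter.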

Compound 3, half-maximal inhibitory concentration: 17 ug/mL
Estimate against measurement, compound 3: 2.1-fold (0.33 log units) below; low and high end bracket the measured number.
By their numbers in this assay, from the lowest: compound 1; then compounds 3 and 2 (each within the scatter of the next).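

In this assay the series now has its first matched step, amino in place of hydrogen on an aromatic nitrogen, and it reads a 2.4-fold higher number from compound 1 to compound 3 (0.38 log units; beyond the scatter). The step is modest but lies beyond the usual scatter, so this position is not indifferent to substitution in this assay: with the rest of the core of compound 1 retained, the change on this aromatic nitrogen alone moves the number upward. No measurement on these compounds accounts for the size or direction of the step, and the data offer no explanation for it.

The compounds shown leave open whether the higher number belongs to amino itself or would follow any group replacing that hydrogen, and a methyl group, a hydroxyl group or a longer chain such as ethyl on the same nitrogen would separate these readings. They also leave open whether a substituted amine in this place, such as a methylamino or an acetylamino group, would keep, widen or reverse the step seen from this single replacement.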